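The source may report more compounds than this note shows. Statements on the series, on what has been measured and on what is new or still open speak of the compounds shown alone.

Working notes on the series, read in a functional assay on Bel-7402 cells (Homo sapiens) for cytotoxicity, read by MTT assay, with a stated time of 24 h; on this read-out higher numbers stand for weaker inhibition and lower numbers for stronger inhibition. Compound 1 (`CC(C)C1=C[C@]2(O)CC[C@H]3[C@]4(C)CCC[C@]3(C(=O)OC4)C2=CC1=O`) gives > 10000 nM, which is a limit of the assay and not a number. Compound 2 (`CC(C)c1cc2c(cc1O)[C@]13CCC[C@]4(C)CO[C@@H]1O[C@H]2C[C@@H]43`) gives > 10000 nM, again a limit. Compound 3 (`CC(C)c1cc2c(cc1O)[C@]13CCC[C@](C)(CO[C@H]1O)[C@@H]3CC2`) gives > 10000 nM, also a limit, so its true position in this assay is not resolved. Among the compounds with values here, the series so far holds no actual number, only (the limit of > 10000 nM in this assay, at which 3 of the 3 values shown sit).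

Compound 4 (`CC(C)c1cc2c(cc1O)[C@]13CCC[C@](C)(CO[C@@H]1O)[C@@H]3CC2`) is the next to be read. It has the same atoms and bonds as compound 3, and the change is the two compounds have the same atoms and bonds and differ only in configuration as drawn: 1 of 4 stereo elements differ; a stereocentre at a saturated ring carbon is drawn R in compound 3 and S in compound 4. Within the data shown here, no step between measured compounds is available to size such a change, so any expectation here is weakly grounded. No shift beyond the scatter is expected in this assay, in either direction, and another report as a limit is the likeliest outcome, given that compound 3 also reads > 10000 nM. The expected size of the change is a step that the limit leaves unreadable from compound 3 to compound 4, which stays within the scatter. For compound 4 the estimated value is 15000 nM, with an expected range of 5000 nM to 50000 nM.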

Compound 4, half-maximal inhibitory concentration: > 10000 nM
Compound 4 ended at the assay's limit; the forecaster's own chance of this, stated with the estimate: 85%; the middle value does not contradict the limit.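

In this assay compound 4 gives > 10000 nM, a limit of the assay and not a number. Compound 3 also reads as a limit, so no step can be read between compound 3 and compound 4. The compounds shown leave open whether the drawn configuration at that saturated ring carbon affects cytotoxicity at all, as no actual number is available: the limit of > 10000 nM in this assay, at which 4 of the 4 values shown sit.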